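A few compounds are considered here, and "the series" means these few. Any claim that something is new, unique, unknown or untested is made for them only; others in the source may bear on it.

Compound 2 `Cc1[nH]n(-c2nc3ccccc3[nH]2)c(=O)c1Cc1ccc(C(F)(F)F)cc1` gives 550 nM in an assay on isolated protein for inhibition of alpha-ketoglutarate-dependent dioxygenase alkB homolog 3 (Homo sapiens), read by polymerase chain reaction, with a stated time of 1 h (on this read-out higher numbers stand for weaker inhibition and lower numbers for stronger inhibition), the lowest of the three numbers, though its neighbours lie within the scatter of it: compound 3 `Cc1ccc2[nH]c(-n3[nH]c(C)c(Cc4ccc(C(F)(F)F)cc4)c3=O)nc2c1` gives 570 nM and compound 1 `Cc1[nH]n(-c2nc3cc(C(F)(F)F)ccc3[nH]2)c(=O)c1Cc1ccccc1` gives 610 nM. Within the data shown here, the only single-place step, a 1.0-fold higher number from compound 2 to compound 3 (0.02 log units; within the scatter), shows that a methyl on the shared core leaves the number essentially unchanged. Compound 4 `Cc1[nH]n(-c2nc3ccccc3[nH]2)c(=O)c1Cc1ccc(F)cc1` differs from compound 2 by fluoro in place of trifluoromethyl on an aromatic carbon. Among the measured compounds shown here, no measured step bears on this change; compounds 1 and 2 differ in more than one place and show only that moving the trifluoromethyl changes little. Compound 4 is therefore expected to give about 800 nM in this assay, within 350 nM to 1800 nM, the expected step of a 1.5-fold higher number from compound 2 to compound 4 (0.16 log units; within the scatter) being small and uncertain.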

Compound 4, half-maximal inhibitory concentration: 600 nM
For compound 4 the middle estimate is 1.3-fold (0.12 log units) above the measured one; the range from low to high includes it.
By their numbers in this assay, from the lowest: compounds 2, 3, 4 and 1 (each within the scatter of the next).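

In this assay, among these compounds, fluoro in place of trifluoromethyl on this aromatic carbon gives a 1.1-fold higher number from compound 2 to compound 4 (0.04 log units; within the scatter), the first reading of a single-place change at this position. The number therefore holds within the scatter when a group of 4 heavy atoms gives way to one of 1 heavy atom. No supporting evidence accounts for this result. The compounds shown leave open whether hydrogen, an amine or a carboxylic acid on this carbon would also leave the number unchanged, and whether a longer chain there would do so.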